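The source may hold more compounds than are shown below. What is called first, only, known or untested is meant among the compounds shown, and "the series" means these compounds.

Compound 1 `CC(C)[C@H](NC(=O)COc1cccc2ccccc12)C(=O)N[C@@H](CC(=O)O)C(=O)CSc1nncn1C` — in a functional assay on Jurkat cells (Homo sapiens) for inhibition (on this read-out higher numbers stand for weaker inhibition and lower numbers for stronger inhibition), compound 1 gives > 200000 nM, a limit.
Compound 2 `Cc1cc(OCC(=O)[C@H](CC(=O)O)NC(=O)[C@@H](NC(=O)COc2cccc3ccccc23)C(C)C)nc(C)n1` — in this assay compound 2 gives > 200000 nM, also a limit.

Both values shown so far are limits of this assay rather than numbers, and compound 2 stands at one of them: the limit of > 200000 nM in this assay, at which 2 of the 2 values shown sit. The step that the two limits leave unreadable from compound 1 to compound 2 runs between two limits and cannot be sized.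

Compound 3 `CC(C)[C@H](NC(=O)COc1cccc2ccccc12)C(=O)N[C@@H](CC(=O)O)C(=O)COc1ncnc2ccccc12` has not yet been measured in this assay. It differs from compound 2 in one place: quinazolin-4-yl in place of 2,6-dimethylpyrimidin-4-yl on an oxygen on a saturated carbon. The only measured step, a step that the two limits leave unreadable from compound 1 to compound 2, is unreadable, so no measured step bears on this change with a readable size, and the change at the oxygen on a saturated carbon has no measured counterpart among these compounds. Going by the values given here, with both measured compounds sitting at the limit and no step pointing either way, compound 3 is expected to stay at or near the limit, a step of a number no higher from compound 2 to compound 3 (the limit leaves the size open) that is expected to be no more than the scatter. The estimate for compound 3 in this assay is 200000 nM, with a range from 60000 nM to 600000 nM, and most likely the assay again reports only a limit.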

Compound 3, half-maximal inhibitory concentration: > 200000 nM
Compound 3: no number, only a limit; the forecaster's own chance of this, stated with the estimate: 75%; the middle value lies on the limit itself.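

Compound 3 also gives only a limit in this assay, so neither its step from compound 2 nor its step from compound 1 can be read or sized. All the values shown now sit at the same limit: the limit of > 200000 nM in this assay, at which 3 of the 3 values shown sit.

The compounds shown leave open how (4-methyl-4H-1,2,4-triazol-3-yl)sulfanyl, (2,6-dimethylpyrimidin-4-yl)oxy and (quinazolin-4-yl)oxy compare in this assay.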